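Aryl substituent series: estimate for compound 4

A few compounds are considered here, and "the series" means these few. Any claim that something is new, unique, unknown or untested is made for them only; others in the source may bear on it.

Measured compounds:
compound 1, `Cc1ccc(-n2cc(COc3cccc(NC(=O)Nc4ccc(Cl)c(C(F)(F)F)c4)c3)nn2)cc1`, gives 5430 nM in a functional assay on HepG2 cells (Homo sapiens) for inhibition, read by MTT assay, with a stated time of 72 h; on this read-out higher numbers stand for weaker inhibition and lower numbers for stronger inhibition
compound 2, `N#Cc1cccc(-n2cc(COc3cccc(NC(=O)Nc4ccc(Cl)c(C(F)(F)F)c4)c3)nn2)c1`, gives 2760 nM in this assay
compound 3, `CCc1cccc(-n2cc(COc3cccc(NC(=O)Nc4ccc(Cl)c(C(F)(F)F)c4)c3)nn2)c1`, gives 37900 nM in this assay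

Compound 2 has the lowest number of the three, but its step from compound 1, a 2.0-fold lower number from compound 1 to compound 2 (0.29 log units; within the scatter), is within the scatter; only compound 3 is clearly apart, by a 14-fold higher number from compound 2 to compound 3 (1.14 log units; beyond the scatter).

Compound 4 is `O=C(Nc1cccc(OCc2cn(-c3cccc(I)c3)nn2)c1)Nc1ccc(Cl)c(C(F)(F)F)c1`. Its change from compound 2: iodo in place of cyano on an aromatic carbon. Within the data shown here, the one step that bears on it is the exchange of cyano on the same carbon, a 14-fold higher number from compound 2 to compound 3 (1.14 log units; beyond the scatter), a large loss; a 7.0-fold higher number from compound 1 to compound 3 (0.84 log units; beyond the scatter) also points toward weaker inhibition for this position. A higher number than compound 2 is therefore expected for compound 4 in this assay, though smaller than the ethyl case. For compound 4 the expected step is a 3.3-fold higher number from compound 2 to compound 4 (0.51 log units; beyond the scatter).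

Compound 4 is estimated at 9000 nM, range 3000 nM to 30000 nM.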

Compound 4, half-maximal inhibitory concentration: 4780 nM
Beside the measured number, compound 4's estimate is 1.9-fold (0.27 log units) above it; measured number inside the range.
By their numbers in this assay, from the lowest: compounds 2, 4 and 1 (each within the scatter of the next); then compound 3.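

In this assay, the ethyl result does not extend to every replacement of cyano on this aromatic carbon: iodo stays level with cyano, with a 1.7-fold higher number from compound 2 to compound 4 (0.24 log units; within the scatter), and is clearly apart from ethyl, with a 7.9-fold lower number from compound 3 to compound 4 (0.90 log units; beyond the scatter). The change of aryl group also leaves no separation, with a 1.1-fold lower number from compound 1 to compound 4 (0.06 log units; within the scatter), so compound 3 alone stands apart among the four. No evidence is available to account for the gap between iodo and ethyl.

Still open, on these data alone, is whether an amine, a carboxylic acid or a chain longer than ethyl on this carbon would stay level with cyano and iodo or move apart as ethyl does.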